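Swapping methoxy for cyclopropyl on the aryl ring of compound 1

The source may report more compounds than this note shows. Statements on the series, on what has been measured and on what is new or still open speak of the compounds shown alone.

compound 1 `COc1ccccc1N1CCN(CCCNc2ncccc2C(=O)N(C)C)CC1` — 1.59 nM
compound 2 `COc1ccccc1N1CCN(CCCNc2ncccc2C(=O)C2CC2)CC1` — 0.501 nM
compound 3 `COc1ccccc1N1CCN(CCCNc2ccc(C(=O)N(C)C)cn2)CC1` — 25.1 nM

Of the compounds shown here, three have been measured in a functional assay for antagonist activity at Alpha-1A adrenergic receptor (Oryctolagus cuniculus); a lower number here means tighter binding, a higher number weaker binding. Among their numbers compound 1 stands second highest. Among the measured compounds shown here, the only measured single-site step is a 3.2-fold lower number from compound 1 to compound 2 (0.50 log units; beyond the scatter), which makes compound 2 the nearest neighbour of compound 1. Compound 3 lies furthest away, and the two values show a markedly higher number for compound 3 than for compound 1.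

The new compound is compound 4 `CN(C)C(=O)c1cccnc1NCCCN1CCN(c2ccccc2C2CC2)CC1`. It differs from compound 1 as follows: cyclopropyl in place of methoxy on an aromatic carbon. For the measured compounds named here, the change sits on an aromatic carbon of a six-membered aromatic ring of carbon only, ortho to a large group, whereas the one measured step exchanges a group on a carbonyl carbon; that step therefore bears on the new change only in the loose sense that it too introduces cyclopropyl, and it went toward a lower number. Going by the values given here, no measured step touches the methoxy position itself. Given that, a modest rise in the number for compound 4 is expected, the estimated step being a 3.1-fold higher number from compound 1 to compound 4 (0.50 log units; beyond the scatter). In this assay compound 4 is expected to give about 5 nM, with a likely range from 1.5 nM to 16 nM.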

Compound 4, dissociation constant: 0.631 nM
Compound 4: the middle estimate sits 7.9-fold (0.90 log units) above what was measured; the whole stated range lies above it.
By their numbers in this assay, from the lowest: compounds 2 and 4 (each within the scatter of the next); then compound 1; then compound 3.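

In this assay, among the compounds shown here, the change from 2-methoxyphenyl to 2-cyclopropylphenyl gives a 2.5-fold lower number from compound 1 to compound 4 (0.40 log units; beyond the scatter), the first measured step at this place on the aromatic ring, and it shows that the methoxy group can be replaced there without a rise in the number, even though its one hydrogen-bond acceptor leaves and a three-membered ring of carbon enters. Cyclopropyl now goes with a lower number at two separate sites, as the earlier step on the carbonyl carbon, a 3.2-fold lower number from compound 1 to compound 2 (0.50 log units; beyond the scatter), also points the same way, and neither of the two listed steps that bring in this group goes against that, although two steps at different sites make only a slender pattern. Nothing measured alongside these values accounts for the direction of the new step, so the reason for it stays unknown.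

The compounds shown leave open whether the lower number belongs to cyclopropyl itself or would also appear with an ethyl, an isopropyl, a cyclobutyl or a chlorine on the same aromatic carbon. They also leave open what a single compound carrying both the 2-cyclopropylphenyl group and the cyclopropyl on the carbonyl carbon would give, and whether the two changes would add up.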